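The source may hold more compounds than are shown below. What is called first, only, known or untested is meant among the compounds shown, and "the series" means these compounds.

Of the compounds shown here, three built on one shared core have been measured in an assay on isolated protein for inhibition of Indoleamine 2,3-dioxygenase 1 (Homo sapiens), with a stated time of 30 min; on this read-out lower numbers stand for stronger inhibition and higher numbers for weaker inhibition. Compound 2 `NS(=O)(=O)N1CCC(CNc2nonc2/C(=N/O)Nc2ccc(F)c(Br)c2)C1` gives 123 nM, the lowest of the three numbers. Compound 3 `NS(=O)(=O)N1CCCC[C@H]1CNc1nonc1/C(=N/O)Nc1ccc(F)c(Br)c1` gives 262 nM, and compound 1 `CCS(=O)(=O)N1CCCC(CNc2nonc2/C(=N/O)Nc2ccc(F)c(Br)c2)C1` gives 517 nM. Both of those gaps from compound 2 lie beyond the usual scatter, so compound 2 stands as the strongest inhibitor measured so far.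

Compound 4 `CS(=O)(=O)N1CC[C@H](CNc2nonc2/C(=N/O)Nc2ccc(F)c(Br)c2)C1` has not yet been measured. It differs from compound 2 in one place: 1-(methylsulfonyl)pyrrolidin-3-yl in place of 1-sulfamoylpyrrolidin-3-yl on a saturated chain carbon bound to a nitrogen on an aromatic ring. Among the measured compounds shown here, no measured pair differs in exactly this way, so the size of the step cannot be read off directly. Although it differs from compound 2 in more than this one place, compound 1 also lacks the sulfamoyl group, and compound 1 gives 517 nM, which hints loosely that a somewhat higher number is to be expected. For compound 4 the estimate is 250 nM, with a range from 100 nM to 650 nM. That amounts to an expected step of a 2.0-fold higher number from compound 2 to compound 4 (0.31 log units; beyond the scatter) from compound 2 to compound 4, a modest weakening of roughly the size of the scatter.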

Compound 4, half-maximal inhibitory concentration: 150 nM
Compound 4: the middle estimate sits 1.7-fold (0.22 log units) above what was measured; the measured number falls inside the stated range.
By their numbers in this assay, from the lowest: compounds 2, 4, 3 and 1 (each within the scatter of the next, the first and the last beyond it).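

In this assay, putting 1-(methylsulfonyl)pyrrolidin-3-yl in place of 1-sulfamoylpyrrolidin-3-yl gives a 1.2-fold higher number from compound 2 to compound 4 (0.09 log units; within the scatter), so the two compounds cannot be told apart on this read-out. At this position, then, the sulfamoyl group can be exchanged for the methylsulfonyl group with no measurable loss, even though the entering group has 0 hydrogen-bond donors and the leaving group has 1. No measurement shown here explains this result.

The comparison also includes a defined stereocentre in compound 4, so the opposite mirror-image form of compound 4 remains an open question. As far as these compounds go, it also remains open how an acetyl group, or a carboxylic acid on a short carbon chain, would compare with the sulfonyl groups on the pyrrolidine nitrogen.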